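Thiophen-2-yl for 3-Fluorophenyl in a Series at the Limit

The source may hold more compounds than are shown below. What is called first, only, known or untested is meant among the compounds shown, and "the series" means these compounds.

Three compounds share one core and differ in the groups attached to it. Compound 1 `CCc1cc(Cc2cccc(OC)c2)c(=O)n(CC(=O)Nc2ccc(I)cc2)n1`, compound 2 `COc1cccc(Cc2cc(-c3cccs3)nn(CC(=O)Nc3ccc(F)cc3)c2=O)c1` and compound 3 `Cc1cc(Cc2cccc(F)c2)c(=O)n(CC(=O)Nc2ccc(Br)cc2)n1` were each tested in an assay on HL-60 cells for agonist activity at N-formyl peptide receptor 3 (Homo sapiens), read by calcium flux; a lower number here means that less compound is needed, a higher number that more compound is needed for the effect. In this assay compound 1 gives only a limit, > 50000 nM. Compound 2 likewise reaches only the limit of this assay, > 50000 nM. For compound 3 this assay also reports a limit rather than a number, > 50000 nM. Compound 3 therefore stands nowhere in particular among these values: the limit of > 50000 nM in this assay, at which 3 of the 3 values shown sit, so no measured step separates any pair of them, and nothing can be said about how one group compares with another on the numbers shown.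

Compound 4 `Cc1cc(Cc2cccs2)c(=O)n(CC(=O)Nc2ccc(Br)cc2)n1` has not yet been measured in this assay. It differs from compound 3 in one place: thiophen-2-yl in place of 3-fluorophenyl on a saturated chain carbon bound to an aromatic carbon. With every measured neighbour sitting at the limit, the step that compound 4 is expected to show, a number no higher from compound 3 to compound 4 (the limit leaves the size open), is none beyond the scatter in either direction, and another limit is the most likely outcome. Compound 4 is accordingly expected to give about 50000 nM in this assay, with a range from 10000 nM to 200000 nM.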

Compound 4, half-maximal effective concentration: 10200 nM
Estimate against measurement, compound 4: 4.9-fold (0.69 log units) above; the range from low to high includes it.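

Within the data shown here, putting thiophen-2-yl in place of 3-fluorophenyl on a saturated chain carbon bound to an aromatic carbon gives, in this assay, an at least 4.9-fold lower number from compound 3 to compound 4 (0.69 log units; beyond the scatter), the first step that can be read at all. The group at this position can therefore move the read-out, a thing the earlier compounds could not show, and here this single exchange is enough to bring compound 4 off the limit where the others remain: the limit of > 50000 nM in this assay, at which 3 of the 4 values shown sit.

Among these compounds, compound 4, at 10200 nM, gives the series its only true number. From the compounds shown here alone, compound 3 gives only a limit, so the full size of the step stays open.

All other steps among the compounds shown cannot be read, and it remains unknown whether thiophen-2-yl would have the same result alongside the other groups carried by compound 1 or compound 2. The compounds shown also leave open how a furan-2-yl or a pyridin-2-yl group at this place would compare with thiophen-2-yl, and whether the sulfur atom of the ring has any part in the result.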